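From ethyl to methoxy: compound 1 to compound 4

A few compounds are considered here, and "the series" means these few. Any claim that something is new, unique, unknown or untested is made for them only; others in the source may bear on it.

Values from an ADME assay on MCF-10A cells (Homo sapiens) for cytotoxicity, read by WST assay, with a stated time of 48 h (on this read-out lower numbers stand for stronger inhibition and higher numbers for weaker inhibition), follow, each a limit and not a number
- compound 1 `CCc1cccc(NC(=S)NNC(=O)c2ccncc2)c1` gives > 300000 nM
- compound 2 `O=C(NNC(=S)Nc1ccc(I)cc1)c1ccncc1` gives > 300000 nM
- compound 3 `O=C(NNC(=S)Nc1ccc(S(=O)(=O)Nc2ncccn2)cc1)c1ccncc1` gives > 300000 nM

Compound 1 is reported only as a limit (> 300000 nM). Compound 2 and compound 3 stand in the same place, so the set offers one shared position (the limit of > 300000 nM in this assay, at which 3 of the 3 values shown sit) and no ranking.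

Compound 4 `COc1cccc(NC(=S)NNC(=O)c2ccncc2)c1` differs from compound 1 in one place, with methoxy in place of ethyl on an aromatic carbon, meta to a large group (methoxy in place of ethyl on an aromatic carbon). No pair of measured compounds gives a step in this assay, so the size of such a change is not shown directly. No step beyond the scatter is expected, in either direction. That expectation rests on compound 1 (> 300000 nM) and on the shared position of the set (the limit of > 300000 nM in this assay, at which 3 of the 3 values shown sit). The estimated change is a number no higher from compound 1 to compound 4 (the limit leaves the size open) as a working figure. For compound 4 the estimate is 300000 nM (estimated range 100000 nM to 500000 nM), and a report as a limit only is the expected outcome.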

Compound 4, half-maximal inhibitory concentration: > 300000 nM
Compound 4 gave a limit, no number (the forecaster's own chance of this, stated with the estimate: 80%); the middle value sits exactly at the limit.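

No step can be read between compound 1 and compound 4; each is reported only as a limit, and methoxy in place of ethyl stays without a readable size. The compounds shown leave open which change to the shared core would give a number in this assay.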